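A Methoxy-to-Chloro Swap Tested at the Assay Limit

The compounds below may be only part of what the source reports. "The series", "measured", "known", "first", "only" and "open" are said of these compounds alone.

Three compounds were tested in a functional assay on HepG2 cells (Homo sapiens) for inhibition, read by MTT assay, with a stated time of 48 h; a higher number here means a weaker inhibitor, a lower number a stronger inhibitor. Compound 1 `COc1ccc(NC(=O)CSc2nnc(-c3cc(OC)c(OC)c(OC)c3)n2-c2ccc(OC)cc2)cc1` gives > 60000 nM there, which is a limit of the assay rather than a number. Compound 2 `COc1ccc(-n2c(SCC(=O)Nc3ccc(Cl)cc3)nnc2-c2cc(OC)c(OC)c(OC)c2)cc1` differs from compound 1 by chloro in place of methoxy on an aromatic carbon. In this assay compound 2 gives > 60000 nM, again a limit. Compound 3 `COc1ccc(NC(=O)CSc2nnc(-c3cc(OC)c(OC)c(OC)c3)n2-c2ccc(N(C)C)cc2)cc1` differs from compound 1 by dimethylamino in place of methoxy on an aromatic carbon. In this assay compound 3 gives > 60000 nM, also a limit. The step that the two limits leave unreadable from compound 1 to compound 2 and the step that the two limits leave unreadable from compound 1 to compound 3 are therefore unreadable, because of the limit of > 60000 nM in this assay, at which 3 of the 3 values shown sit. Compound 4 `COc1cc(-c2nnc(SCC(=O)Nc3ccc(Cl)cc3)n2-c2ccc(N(C)C)cc2)cc(OC)c1OC` is not yet measured; it differs from compound 3 by chloro in place of methoxy on an aromatic carbon, the same change that turns compound 1 into compound 2. Since all measured values sit at the limit of > 60000 nM in this assay, at which 3 of the 3 values shown sit, the step is expected to be a step that the limit leaves unreadable from compound 3 to compound 4. Compound 4 is expected to give about 90000 nM, between 40000 nM and 250000 nM.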

Compound 4, half-maximal inhibitory concentration: > 60000 nM
Compound 4 ended at the assay's limit; the forecaster's own chance of this, stated with the estimate: 85%; the middle value does not contradict the limit.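

No step can be read from compound 3 to compound 4 or from compound 2 to compound 4, because every value is a limit rather than a number: the limit of > 60000 nM in this assay, at which 4 of the 4 values shown sit.

The compounds shown leave open whether either swap, chloro or dimethylamino in place of methoxy, changes inhibition at all.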